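Working notes: one group exchanged on compound 2

The source may hold more compounds than are shown below. What is called first, only, known or untested is meant among the compounds shown, and "the series" means these compounds.

Measured in a functional assay on MOLT-4 cells (Homo sapiens); on this read-out lower numbers stand for stronger inhibition and higher numbers for weaker inhibition
- compound 1 `Cn1ncc2c1[C@@H](CO[Si](c1ccccc1)(c1ccccc1)C(C)(C)C)C[C@H]2Cn1cnc2c(O)ncnc21` gives 3.2 ug/mL
- compound 2 `Cn1ncc2c1[C@H](Cn1cnc3c(Cl)ncnc31)C[C@@H]2CO[Si](c1ccccc1)(c1ccccc1)C(C)(C)C` gives 3.2 ug/mL

Compound 2 at 3.2 ug/mL stands level with compound 1 at 3.2 ug/mL within the scatter. Compound 3 `Cn1ncc2c1[C@H](Cn1ccc(=O)[nH]c1=O)C[C@@H]2CO[Si](c1ccccc1)(c1ccccc1)C(C)(C)C` differs from compound 2 by one exchange (a group of 8 heavy atoms (4 carbon, 2 nitrogen, 2 oxygen; one six-membered aromatic ring with 2 hetero atoms) in place of a group of 10 heavy atoms (5 carbon, 4 nitrogen, 1 chlorine; one five-membered aromatic ring with 2 hetero atoms, one six-membered aromatic ring with 2 hetero atoms), on a saturated chain carbon bound to a saturated ring carbon). For the measured compounds named here, no measured pair shows a step for this exchange, so the expectation rests on compound 2 at 3.2 ug/mL alone, and no change beyond the scatter is expected in this assay for it. The expected shift is small: a 1.1-fold higher number from compound 2 to compound 3 (0.04 log units; within the scatter) in the estimate. Compound 3 is estimated at 3.5 ug/mL within 1.5 ug/mL to 10 ug/mL as the expected range.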

Compound 3, half-maximal inhibitory concentration: 3.2 ug/mL
Compound 3: the middle estimate sits 1.1-fold (0.04 log units) above what was measured; measured number inside the range.
By their numbers in this assay, from the lowest: compounds 1, 2 and 3 (each within the scatter of the next).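

In this assay, placing the group of 8 heavy atoms in the position of the group of 10 heavy atoms, on a saturated chain carbon bound to a saturated ring carbon, gives no change at the digits printed from compound 2 to compound 3 (within the scatter). This position therefore accepts a single six-membered aromatic ring carrying a hydrogen-bond donor in place of the fused chlorine-bearing group, with no shift beyond the scatter. No available evidence accounts for this. On these data alone, whether an amine or a carboxylic acid on this chain carbon would hold the read-out remains open.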